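Replacing a Carbamate with an Aminobenzamide in a Cytotoxic Sulfonylurea

The source may report more compounds than this note shows. Statements on the series, on what has been measured and on what is new or still open speak of the compounds shown alone.

Measured compounds:
compound 1 `CCc1cc(S(=O)(=O)N2C[C@H](c3ccccc3)NC2=O)ccc1NC(=O)OC(C)C`: 60 nM
compound 2 `CCOC(=O)Nc1ccc(S(=O)(=O)N2C(=O)N[C@@H](c3ccccc3)C2C)cc1Cl`: 6000 nM
compound 3 `CCOC(=O)Nc1ccc(S(=O)(=O)N2C(=O)N[C@@H](c3ccccc3)C2C)cc1C`: 5000 nM

In a functional assay on NCI-H460 cells (Homo sapiens) for cytotoxicity, read by MTT assay (a higher number here means a weaker inhibitor, a lower number a stronger inhibitor), compound 1 gives the lowest number of the three; compound 3 and compound 2 both sit higher, and both gaps lie beyond the scatter. Going by the values given here, the only measured single-point step, a 1.2-fold lower number from compound 2 to compound 3 (0.08 log units; within the scatter), concerns an aromatic substituent and does not touch the carbamate end of the molecule.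

Compound 4 `CCc1cc(S(=O)(=O)N2C[C@H](c3ccccc3)NC2=O)ccc1NC(=O)c1ccc(N)cc1` differs from compound 1 by 4-aminophenyl in place of isopropoxy on a carbonyl carbon. Among the compounds with values here, no measured pair speaks to this exchange, so its effect is unknown. The estimate for compound 4 is therefore centred on 200 nM with a wide range from 30 nM to 2000 nM, meaning an expected step of a 3.3-fold higher number from compound 1 to compound 4 (0.52 log units; beyond the scatter).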

Compound 4, half-maximal inhibitory concentration: 670 nM
For compound 4 the middle estimate is 3.4-fold (0.53 log units) below the measured one; low and high end bracket the measured number.
By their numbers in this assay, from the lowest: compound 1; then compound 4; then compounds 3 and 2 (each within the scatter of the next).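

The step of an 11-fold higher number from compound 1 to compound 4 (1.05 log units; beyond the scatter) shows that the carbonyl end of the molecule, untouched by the earlier aromatic step, strongly affects cytotoxicity in these cells. With the rest of compound 1 unchanged, the isopropoxy group gives a much lower number than 4-aminophenyl at this position. Nothing available explains this difference.

On these data alone, because the ring and its amine enter together, their separate contributions remain open. A plain phenyl, or a methoxy group on the same carbonyl carbon, would show how much of the difference follows each part.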